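The compounds below may be only part of what the source reports. "The series", "measured", "known", "first", "only" and "open" are said of these compounds alone.

Working notes on the series, read in an ADME assay on HEK293 cells (Homo sapiens) for inhibition, read by MTT assay, with a stated time of 48 h; on this read-out lower numbers stand for stronger inhibition and higher numbers for weaker inhibition. Compound 1 `CS(=O)(=O)c1ccc(-c2nc3ccccn3c2Sc2ccccc2)cc1` gives > 100000 nM, which is a limit. Compound 2 `CCc1ccc(-c2nc3ccccn3c2Sc2ccccc2)cc1` gives > 100000 nM, also a limit and not a number. Among the compounds with values here, the series so far shows (the limit of > 100000 nM in this assay, at which 2 of the 2 values shown sit). Compound 3 `Cc1ccc(-c2nc3ccccn3c2Sc2ccccc2)cc1` differs from compound 2 by hydrogen in place of methyl on a saturated chain carbon bound to an aromatic carbon. Within the data shown here, the only measured step, a step that the two limits leave unreadable from compound 1 to compound 2, gives no size to carry over, so no change beyond the scatter is expected. The expected step is a number no higher from compound 2 to compound 3 (the limit leaves the size open). Compound 3 is estimated at 100000 nM, with an expected range of 40000 nM to 200000 nM.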

Compound 3, half-maximal inhibitory concentration: > 100000 nM
Compound 3: a limit, no number; the forecaster's own chance of this, stated with the estimate: 85%; the middle value lies on the limit itself.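

Within the data shown here, compound 1, compound 2 and compound 3 all stand as limits in this assay and no step among them can be read. The compounds shown leave open whether methylsulfonyl, ethyl or methyl changes the read-out at all.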